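Methyl on an Aromatic Nitrogen in Two Urea Series

A few compounds are considered here, and "the series" means these few. Any claim that something is new, unique, unknown or untested is made for them only; others in the source may bear on it.

Three ureas have been measured in an assay on CHO-K1 cells for antagonist activity at transient receptor potential cation channel subfamily V member 1 (Homo sapiens), read by FLIPR and calcium flux, with a stated time of 6 min; a higher number here means a weaker inhibitor, a lower number a stronger inhibitor:

Compound 1, `O=C(NCc1cc(C(F)(F)F)nn1-c1ccc(F)c(Cl)c1)Nc1cccc2[nH]ncc12`: 0.6 nM
Compound 2, `Cn1ncc2c(NC(=O)NCc3cc(C(F)(F)F)nn3-c3ccc(F)c(Cl)c3)cccc21`: 1.9 nM
Compound 3, `CC(C)(C)c1cc(CNC(=O)Nc2cccc3[nH]ncc23)n(-c2cccc(C(F)(F)F)c2)n1`: 0.3 nM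

Compound 2 differs from compound 1 by methyl in place of hydrogen on an aromatic nitrogen, and this change produced a 3.2-fold higher number from compound 1 to compound 2 (0.50 log units; beyond the scatter). Compound 3 rests on another core; how the core of compound 3 differs from that of compound 1 is not broken down here. Set against compound 3, compound 1 gives a number within the scatter, whereas compound 2 lies beyond it.

Compound 4, `Cn1ncc2c(NC(=O)NCc3cc(C(C)(C)C)nn3-c3cccc(C(F)(F)F)c3)cccc21`, is not yet measured. It differs from compound 3 by methyl in place of hydrogen on an aromatic nitrogen, the same change that separates compound 1 from compound 2, at the same place in both cases. Going by the values given here, because the one measured step of this kind was a 3.2-fold higher number from compound 1 to compound 2 (0.50 log units; beyond the scatter), a step of similar size is expected from compound 3 to compound 4 in this assay, namely a 3.3-fold higher number from compound 3 to compound 4 (0.52 log units; beyond the scatter). Compound 4 is therefore estimated at 1 nM, with a likely range from 0.4 nM to 2.5 nM.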

Compound 4, inhibition constant: 0.6 nM
Compound 4: the middle estimate sits 1.7-fold (0.22 log units) above what was measured, and the stated range covers the measured number.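

In this assay, methyl in place of hydrogen on the aromatic nitrogen gave a 2.0-fold higher number from compound 3 to compound 4 (0.30 log units; within the scatter). Set beside the earlier step, the two cores cannot be told apart in their response to this change: the same change on two cores in this assay, a 3.2-fold higher number (0.50 log units; beyond the scatter) from compound 1 to compound 2 and a 2.0-fold higher number (0.30 log units; within the scatter) from compound 3 to compound 4, 1.6-fold (0.20 log units) apart, within the scatter of two such steps. This shows that the size of the step carried over from one core to the other as far as these two pairs can tell, but the new step alone lies within the scatter, so it does not show a real difference within that pair, and two pairs do not make a rule for the whole series.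

On these data alone, what an ethyl group, a longer chain or a chain ending in an amine or a carboxylic acid would do on this same nitrogen remains open. Also open, as far as these compounds go, is whether methyl on this nitrogen would give a step of similar size on a third core, or on any core in a different read-out.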